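This account rests on a few compounds, and the source may have more. Where it says the series, first, only, none or still open, it means among the compounds named here.

Of the compounds shown here, three have been measured in a functional assay on NCI-H460 cells (Homo sapiens) for antiproliferative activity, read by CCK-8 assay, with a stated time of 72 h, tested at 8 uM; on this read-out lower numbers stand for a weaker effect and higher numbers for a stronger effect at the one concentration tested. Compound 3 `CC(C)n1cnc2c(NCc3ccc(C(=O)Nc4ccccc4N)cc3)nc(Cl)nc21` gives 80.5%, compound 1 `CC(C)n1cnc2c(Nc3ccccc3)nc(NCOCc3ccc(/C=C/C(=O)Nc4ccccc4N)cc3)nc21` gives 53.1%, and compound 2 `CCCCn1cnc2c(NCc3ccc(C(=O)Nc4ccccc4N)cc3)nc(Cl)nc21` gives 23.7%. Compound 2 differs from compound 3 in one place, (butyl in place of isopropyl on an aromatic nitrogen), and this change made a step of a number 56.8 percentage points lower from compound 3 to compound 2 (beyond the scatter). Compound 1 and compound 3 differ in more than one place; the difference between the two cores is not broken down here.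

Compound 4 `CCCCn1cnc2c(Nc3ccccc3)nc(NCOCc3ccc(/C=C/C(=O)Nc4ccccc4N)cc3)nc21` has not yet been measured. It differs from compound 1 by butyl in place of isopropyl on an aromatic nitrogen, the same change as between compound 3 and compound 2, at the same place. Since compound 1 stands at 53.1% in this assay, a step as large as a number 56.8 percentage points lower from compound 3 to compound 2 (beyond the scatter) would leave little of the effect. Compound 4 is therefore expected at 10%, with an estimated range from 0% to 35%. That is an expected step of a number 43.1 percentage points lower from compound 1 to compound 4 (beyond the scatter), resting on compound 1 at 53.1% and on the earlier step of a number 56.8 percentage points lower from compound 3 to compound 2 (beyond the scatter).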

Compound 4, a percentage reported as inhibition, at one concentration (the size of the read-out at that concentration, not a potency): 34.2%
Estimate against measurement, compound 4: 24.2 percentage points below; the measured number falls inside the stated range.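

The change of butyl in place of isopropyl on an aromatic nitrogen also lowers the number in this assay on the second core, with a number 18.9 percentage points lower from compound 1 to compound 4 (beyond the scatter) in this pair. The direction of the step carries over between the two pairs shown, but its size does not carry over: the same change on two cores in this assay, a number 56.8 percentage points lower (beyond the scatter) from compound 3 to compound 2 and a number 18.9 percentage points lower (beyond the scatter) from compound 1 to compound 4, 37.9 percentage points apart, beyond the scatter of two such steps. This does not show which of the several differences between the two cores sets the size of the step, and two pairs give no rule for what the same change would do on a further core.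

The compounds shown leave open how other groups on that aromatic nitrogen would read on either core, such as ethyl, a cyclopentyl ring or a longer chain ending in an amine. They also leave open whether the same change would lower the number in other cell lines.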